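Swapping a methoxy for chloro on an aryl piperazine

A few compounds are considered here, and "the series" means these few. Any claim that something is new, unique, unknown or untested is made for them only; others in the source may bear on it.

Of the compounds shown here, two with a shared core have been tested in a functional assay on the whole organism (strain Wister albino) for inhibition, with Rattus norvegicus as the target, read by paw edema, with stated times of 30 min and 3 h, at a dose of 10 mg/kg by the oral route; on this read-out lower numbers stand for less inhibition and higher numbers for more inhibition at the one dose given (going by the name of the read-out). Compound 1 `CCOC(=O)C1CCN(Cn2nc(C(C)c3ccc(CC(C)C)cc3)oc2=S)CC1` gives 73.9% in this assay. Compound 2 `COc1ccc(N2CCN(Cn3nc(Cc4ccc(SC)cc4)oc3=S)CC2)cc1` gives 33.7% in this assay, which puts compound 2 at the lower of the two numbers; compound 1 sits well above it, by more than the usual scatter of this kind of measurement. The two differ in several places at once, so no single change can be tied to that gap.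

Compound 3 `CSc1ccc(Cc2nn(CN3CCN(c4ccc(Cl)cc4)CC3)c(=S)o2)cc1` has not yet been measured. It differs from compound 2 in one place: chloro in place of methoxy on an aromatic carbon. Within the data shown here, no measured pair in this set shows what such a change does, so the step from compound 2 to compound 3 is expected to be small, a number 2.3 percentage points higher from compound 2 to compound 3 (within the scatter), with no clear direction beyond the scatter. Compound 3 is therefore estimated at 36%, with a likely range from 15% to 60%.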

Compound 3, a percentage reported as inhibition, in the whole organism at one dose (the size of the read-out at that dose, not a potency): 71.1%
For compound 3 the middle estimate is 35.1 percentage points below the measured one; the measured number lies above the stated range.
By their numbers in this assay, from the lowest: compound 2; then compounds 3 and 1 (each within the scatter of the next).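

Among these compounds, this is the first comparison in the set that isolates one change: in this assay, putting chloro in place of methoxy on an aromatic carbon, para to a large group, gives a number 37.4 percentage points higher from compound 2 to compound 3 (beyond the scatter) with the rest of the molecule unchanged. This position is therefore not indifferent to its substituent, since exchanging methoxy, with its two heavy atoms and one hydrogen-bond acceptor, for a single chlorine atom moves the read-out by a large step. No measurement at hand explains why the number moves.

Among the compounds shown here, with only two groups seen at this position, it remains open whether fluoro, methyl or an amine would read like chloro or like methoxy. From the compounds shown here alone, it is also open whether the same swap would give a similar step in a compound with a different group on the other side of the shared core.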